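Three Substituents on the Thiocarbonyl Carbon, One Shared Core

A few compounds are considered here, and "the series" means these few. Any claim that something is new, unique, unknown or untested is made for them only; others in the source may bear on it.

Three compounds share one core and differ only in the group on a thiocarbonyl carbon. Compound 1 `Nc1ccccc1NC(=O)c1ccc(CSC(=S)N2CCc3ccccc32)cc1` gives 85.4% in a functional assay on A-375 cells (Homo sapiens) for antiproliferative activity, read by CCK-8 assay, with a stated time of 72 h, tested at 8 uM; on this read-out higher numbers stand for a stronger effect at the one concentration tested and lower numbers for a weaker effect. Compound 2 `CN(C(=S)SCc1ccc(C(=O)Nc2ccccc2N)cc1)c1cccnc1` gives 87.7% in the same assay, and compound 3 `CC1CCCCN1C(=S)SCc1ccc(C(=O)Nc2ccccc2N)cc1` gives 85.2%. Compound 3 stands alongside both: the step of a number 0.2 percentage points lower from compound 1 to compound 3 (within the scatter) and the step of a number 2.5 percentage points lower from compound 2 to compound 3 (within the scatter) both lie within the scatter, as does a number 2.3 percentage points higher from compound 1 to compound 2 (within the scatter).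

Compound 4 `CCN(Cc1ccncc1)C(=S)SCc1ccc(C(=O)Nc2ccccc2N)cc1` has not yet been measured. It differs from compound 3 in one place: ethyl((pyridin-4-yl)methyl)amino in place of 2-methylpiperidin-1-yl on a thiocarbonyl carbon.

Among the measured compounds shown here, the steps that bear on this change are those that alter the same position, from compound 1 to compound 3 and from compound 2 to compound 3. Neither moved the read-out beyond the scatter, and the group entering in compound 4 resembles that of compound 2 in carrying a pyridine ring on this nitrogen. Compound 4 is therefore expected to give a number close to that of compound 3, with the expected step of a number 0.8 percentage points higher from compound 3 to compound 4 (within the scatter) in no particular direction. The estimate for compound 4 is 86%, expected to fall between 76% and 95%.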

Compound 4, a percentage reported as inhibition, at one concentration (the size of the read-out at that concentration, not a potency): 86.2%
Compound 4: the middle estimate sits 0.2 percentage points below what was measured, and the stated range covers the measured number.
By their numbers in this assay, from the lowest: compounds 3, 1, 4 and 2 (each within the scatter of the next).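

In this assay, the position on the thiocarbonyl carbon also accommodated ethyl((pyridin-4-yl)methyl)amino, a group of 10 heavy atoms replacing the 7 of 2-methylpiperidin-1-yl, with the change giving a number 1 percentage points higher from compound 3 to compound 4 (within the scatter). The other two comparisons add to this: exchanging methyl(pyridin-3-yl)amino for the new group gave a number 1.5 percentage points lower from compound 2 to compound 4 (within the scatter), and exchanging 2,3-dihydro-1H-indol-1-yl for it gave a number 0.8 percentage points higher from compound 1 to compound 4 (within the scatter), so the four substituents, with or without a pyridine ring and with or without an aromatic ring, cannot be told apart on this read-out. No measurement is available that would explain this lack of separation.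

The compounds shown leave open whether a carboxylic acid, a primary amine or a longer chain such as hexyl on the thiocarbonyl carbon would stay within the same narrow band of values. From the compounds shown here alone, because the read-out in this assay reports the size of the effect at one concentration rather than a potency, it also remains open whether these four compounds would separate at lower concentrations.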